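Swapping a basic side chain for an acid

The compounds below may be only part of what the source reports. "The series", "measured", "known", "first", "only" and "open" are said of these compounds alone.

Compound 2 `CN(C)CCCn1c(Cc2nn(C)c(=O)c3ccccc23)nnc1SCCCCCCCC(=O)Nc1ccc(Cl)cc1Cl` carries a long chain ending in a dichlorophenyl amide, linked through sulfur to a triazole ring that bears a dimethylamino-tipped side chain. In an assay on 32D cells for inhibition of interleukin-15 (Mus musculus), read by resazurin assay, with stated times of 30 min and 2.5 days, in the presence of a further agent that is not named here (on this read-out higher numbers stand for weaker inhibition and lower numbers for stronger inhibition), compound 2 gives 5500 nM. Its closest relative, compound 1 `Cn1c(Cc2nn(C)c(=O)c3ccccc23)nnc1SCCCCCCCC(=O)Nc1ccc(Cl)cc1Cl`, has only a methyl on that ring nitrogen; in this assay compound 1 gives 3900 nM. Going by the values given here, the one step measured, a 1.4-fold higher number from compound 1 to compound 2 (0.15 log units; within the scatter), shows that adding the basic side chain left the number where it was, so compound 2 stands alongside compound 1 rather than apart from it. Compound 3 `Cn1nc(Cc2nnc(SCCCCCCCC(=O)Nc3ccc(Cl)cc3Cl)n2CCC(=O)O)c2ccccc2c1=O` replaces the basic tip with an acid: carboxy in place of (dimethylamino)methyl on a saturated chain carbon, two bonds along the chain from an aromatic nitrogen. Among the compounds with values here, only the step from compound 1 to compound 2 bears on this change, and it was within the scatter. The step from compound 2 to compound 3 is therefore expected to be no change at the digits printed from compound 2 to compound 3 (within the scatter), none beyond the scatter. Compound 3 is estimated at 5500 nM, within 2000 nM to 15000 nM.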

Compound 3, half-maximal inhibitory concentration: > 30000 nM
Compound 3: a limit, no number; the forecaster's own chance of this, stated with the estimate: 15%; middle value at least 5.4-fold (0.73 log units) away from the limit.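

Compound 3 gives only a limit in this assay, not a number: the limit of > 30000 nM in this assay, at which 1 of the 3 values shown sits.

Even so, the limit is enough to read two steps: an at least 5.4-fold higher number from compound 2 to compound 3 (0.73 log units; beyond the scatter), and an at least 7.6-fold higher number from compound 1 to compound 3 (0.88 log units; beyond the scatter). The earlier step suggested that this ring nitrogen could carry a longer chain with little effect on the number, but these steps show that the end of the chain matters: with carboxy in place of (dimethylamino)methyl, inhibition is clearly weaker.

As far as these compounds go, how far compound 3 lies past its limit stays unknown, so the full size of the loss cannot be stated. The compounds shown also leave open whether a methyl ester, a primary amide or a carboxylic acid on a shorter or longer chain at this position would stay close to compound 1.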